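The compounds below may be only part of what the source reports. "The series", "measured", "known", "first", "only" and "open" are said of these compounds alone.

Measured in an ADME assay on MT4 cells (Homo sapiens) for cytotoxicity, read by MTT assay; a lower number here means that less compound is tolerated, a higher number that more compound is tolerated:
- compound 1 `O=C1c2ccccc2C(=O)N1CCOC(=S)N(C(=O)c1cccc([N+](=O)[O-])c1)c1ccc(Cl)cc1`: 18000 nM
- compound 2 `Cc1ccc(N(C(=O)c2cccc([N+](=O)[O-])c2)C(=S)OCCN2C(=O)c3ccccc3C2=O)cc1`: 100000 nM
- compound 3 `Cc1cc(C(=O)N(C(=S)OCCN2C(=O)c3ccccc3C2=O)c2ccc(Cl)cc2)ccc1Br`: 18000 nM

Of these three, compound 2 has the highest number, 100000 nM, so it is the best tolerated. Compound 4 `Cc1ccc(N(C(=O)c2cccc(Cl)c2Cl)C(=S)OCCN2C(=O)c3ccccc3C2=O)cc1` has 2,3-dichlorophenyl in place of 3-nitrophenyl on a carbonyl carbon. The closest guide is a swap at that same kind of place, which gave no change at the digits printed from compound 1 to compound 3 (within the scatter). Among the measured compounds shown here, that is only one example, made with chloro rather than methyl on the other aromatic ring. The swap of methyl in place of chloro gave a 5.6-fold higher number from compound 1 to compound 2 (0.74 log units; beyond the scatter), but compound 4 keeps the methyl, so that step is not repeated here. No step beyond the scatter is therefore expected in this assay, and the expected change is a 1.7-fold lower number from compound 2 to compound 4 (0.22 log units; within the scatter). For compound 4 the estimated value is 60000 nM, with an expected range of 20000 nM to 130000 nM.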

Compound 4, half-maximal cytotoxic concentration: 35000 nM
Estimate against measurement, compound 4: 1.7-fold (0.23 log units) above, within the range that was stated.
By their numbers in this assay, from the lowest: compounds 1, 3 and 4 (each within the scatter of the next); then compound 2.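

In this assay, changing the group on the carbonyl carbon from 3-nitrophenyl to 2,3-dichlorophenyl gives a 2.9-fold lower number from compound 2 to compound 4 (0.46 log units; beyond the scatter). The earlier swap at this kind of place gave no change at the digits printed from compound 1 to compound 3 (within the scatter), so with methyl on the other aromatic ring, this place can shift the number beyond the scatter, at least for this swap. No measurement shown explains the shift.

As far as these compounds go, it remains open whether this same swap would matter with chloro in place of that methyl. An aryl group carrying an amine or a carboxylic acid on this carbonyl carbon also remains untested among the compounds shown.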